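A shorter unsaturated amide and its expected effect

The source may hold more compounds than are shown below. What is called first, only, known or untested is meant among the compounds shown, and "the series" means these compounds.

Compound 1 `C=CC(=O)Nc1ccc(Cn2nc(-c3ccc(Oc4ccccc4)cc3)cc2C(=O)OCC)cc1`: 2800 nM
Compound 2 `C/C=C/C(=O)Nc1ccc(Cn2nc(-c3ccc(Oc4ccccc4)cc3)cc2C(=O)OCC)cc1`: 13100 nM
Compound 3 `C/C=C/C(=O)Nc1cccc(Cn2nc(-c3ccc(Oc4ccccc4)cc3)cc2C(=O)OCC)c1`: 7800 nM

These three compounds were measured in a functional assay on Rec1 cells (Homo sapiens) for inhibition, read by luminescence and CellTiter-Glo, with a stated time of 72 h; a higher number here means a weaker inhibitor, a lower number a stronger inhibitor. Compound 4 `C=CC(=O)Nc1cccc(Cn2nc(-c3ccc(Oc4ccccc4)cc3)cc2C(=O)OCC)c1` has not yet been measured there. Compound 4 differs from compound 3 by one change: vinyl in place of prop-1-en-1-yl on a carbonyl carbon. The same change, in the same place, has already been made once among the measured compounds, from compound 2 to compound 1: vinyl in place of prop-1-en-1-yl on a carbonyl carbon. In this assay it gave a 4.7-fold lower number from compound 2 to compound 1 (0.67 log units; beyond the scatter). The two cores differ in how the same atoms are joined: 3-(((prop-1-en-1-yl)carbonyl)amino)phenyl in place of 4-(((prop-1-en-1-yl)carbonyl)amino)phenyl on a saturated chain carbon bound to an aromatic nitrogen. That change of core gave a 1.7-fold lower number from compound 2 to compound 3 (0.23 log units; within the scatter), while the two changes taken together gave a 2.8-fold higher number from compound 1 to compound 3 (0.44 log units; beyond the scatter). Because a 4.7-fold lower number from compound 2 to compound 1 (0.67 log units; beyond the scatter) was seen for the same change in the same place, the step to compound 4 is expected to be about a 4.1-fold lower number from compound 3 to compound 4 (0.61 log units; beyond the scatter). Compound 4 is therefore estimated to give roughly 1900 nM in this assay, expected between 800 nM and 4500 nM.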

Compound 4, half-maximal inhibitory concentration: 3300 nM
Compound 4: middle estimate off by 1.7-fold (0.24 log units), on the low side; the measured number falls inside the stated range.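

In this assay, vinyl in place of prop-1-en-1-yl on a carbonyl carbon lowered the number on both cores, and the two steps do not differ beyond the scatter: the same change on two cores in this assay, a 4.7-fold lower number (0.67 log units; beyond the scatter) from compound 2 to compound 1 and a 2.4-fold lower number (0.37 log units; beyond the scatter) from compound 3 to compound 4, 2.0-fold (0.30 log units) apart, within the scatter of two such steps. The new step is a 2.4-fold lower number from compound 3 to compound 4 (0.37 log units; beyond the scatter); both changes together give a 4.0-fold lower number from compound 2 to compound 4 (0.60 log units; beyond the scatter), while 3-((vinylcarbonyl)amino)phenyl in place of 4-((vinylcarbonyl)amino)phenyl gives a 1.2-fold higher number from compound 1 to compound 4 (0.07 log units; within the scatter). The change thus carried over between these two cores, but two pairs set no general rule and do not show why it acts.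

The compounds shown leave open whether the step would hold with a carboxylic acid in place of the ester. They also leave open how a longer chain on the carbonyl would compare.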